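Swapping Fluoro for Chloro in Two Related Cores

The compounds below may be only part of what the source reports. "The series", "measured", "known", "first", "only" and "open" are said of these compounds alone.

Compound 1 `C=C[C@@](C)(/C=C/c1ccc(O)c(/C=C/c2ccc(F)cc2)c1)CCC=C(C)C` and compound 2 `C=C[C@@](C)(/C=C/c1ccc(O)c(/C=C/c2ccc(Cl)cc2)c1)CCC=C(C)C` share one core and differ by chloro in place of fluoro on an aromatic carbon. In a functional assay on SEM cells (Homo sapiens) for cytotoxicity, with a stated time of 72 h (a higher number here means that more compound is needed for the effect, a lower number that less compound is needed), compound 1 gives only a limit of > 36600 nM. Compound 2 likewise reaches only a limit of > 36600 nM in this assay. The step that the two limits leave unreadable from compound 1 to compound 2 cannot be read because both values sit at the limit of > 36600 nM in this assay, at which 3 of the 3 values shown sit.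

Compound 3 `CC(C)=CCC[C@](C)(/C=C/c1ccc(O)cc1)/C=C/c1cccc(F)c1` carries a different core; how it differs from the core of compound 1 is not broken down here. In this assay compound 3 also gives only a limit of > 36600 nM.

Compound 4 `CC(C)=CCC[C@](C)(/C=C/c1ccc(O)cc1)/C=C/c1cccc(Cl)c1` is the unmeasured partner of compound 3 and differs from it by chloro in place of fluoro on an aromatic carbon. This is the same kind of change as that from compound 1 to compound 2, though the place is not identical: there the group sits para to a large group, here meta to a large group. Within the data shown here, with every measured value so far resting at the limit of > 36600 nM in this assay, at which 3 of the 3 values shown sit, the step that the limit leaves unreadable from compound 3 to compound 4 is expected to be small and probably unreadable. Compound 4 is therefore expected to give roughly 50000 nM, most likely again only a limit in this assay.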

Compound 4, half-maximal effective concentration: > 36600 nM
Compound 4: a limit, no number; the forecaster's own chance of this, stated with the estimate: 85%; the middle value lies beyond the limit too.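

In this assay compound 4 gives > 36600 nM, which is a limit and not a number. No step can be read between compound 3 and compound 4, since both rest at the same limit: the limit of > 36600 nM in this assay, at which 4 of the 4 values shown sit. The compounds shown leave open whether chloro in place of fluoro changes the effect at all in this assay.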